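The compounds below may be only part of what the source reports. "The series", "measured", "known", "first", "only" and "open" are said of these compounds alone.

In a functional assay on Caco-2 cells (Homo sapiens) for inhibition, read by MTT assay, with a stated time of 48 h, tested at 10 uM (on this read-out higher numbers stand for more inhibition of growth at the one concentration tested and lower numbers for less inhibition of growth), compound 1 (`Cc1cc(=O)c2c(O)c(CN3CCC(Cc4ccccc4)CC3)c(O)c([C@H]3CCN(C)C[C@H]3O)c2o1`) gives 21%, compound 2 (`Cc1oc2c([C@H]3CCN(C)C[C@H]3O)c(O)cc(O)c2c(=O)c1C(O)c1ccc(Cl)cc1`) gives 3% and compound 3 (`Cc1oc2c([C@H]3CCN(C)C[C@H]3O)c(O)cc(O)c2c(=O)c1C(O)c1ccc(F)c(Br)c1`) gives 6%. Compound 3 thus lies within the scatter of compound 2 and beyond the scatter of compound 1, which stands apart as the highest of the three. Compound 4 (`Cc1oc2c([C@H]3CCN(C)C[C@H]3O)c(O)cc(O)c2c(=O)c1C(O)c1csc([N+](=O)[O-])c1`) has not yet been measured. It differs from compound 3 in a single group on a saturated chain carbon bound to an aromatic carbon and an oxygen on a saturated carbon: 5-nitrothiophen-3-yl in place of 3-bromo-4-fluorophenyl on a saturated chain carbon bound to an aromatic carbon and an oxygen on a saturated carbon. For the measured compounds named here, only one measured step bears on this place, a number 3 percentage points higher from compound 2 to compound 3 (within the scatter), and it exchanged one substituted phenyl group for another. Going by the values given here, no measured step shows what a five-membered aromatic ring with a nitro group does here, so the evidence is thin. No step beyond the scatter is expected in this assay, and the estimated step is a number 1 percentage points higher from compound 3 to compound 4 (within the scatter). The estimate for compound 4 is 7%, with an expected range from 0% to 18%.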

Compound 4, percent growth inhibition at one concentration: 3%
Compound 4: middle estimate off by 4 percentage points, on the high side; low and high end bracket the measured number.
By their numbers in this assay, from the lowest: compounds 2, 4 and 3 (each within the scatter of the next); then compound 1.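

In this assay, 5-nitrothiophen-3-yl on this saturated chain carbon gives a number 3 percentage points lower from compound 3 to compound 4 (within the scatter), and in place of 4-chlorophenyl it gives no change at the digits printed from compound 2 to compound 4 (within the scatter). The place therefore accepts a five-membered aromatic ring carrying a nitro group as well as the two substituted phenyl groups, and among compounds 2, 3 and 4 no exchange of these groups moves the read-out beyond the scatter. No evidence is available on why these three groups read alike.

What the compounds shown leave open is whether any group at this place can move the number beyond the scatter, for example an amine, a carboxylic acid or a longer alkyl chain in place of the aromatic ring. They also leave open what the hydroxy group on this same carbon contributes, since it is present in compounds 2, 3 and 4 alike.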